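This account rests on a few compounds, and the source may have more. Where it says the series, first, only, none or still open, it means among the compounds named here.

Measured so far:
Compound 1 `Cc1ccccc1C(=O)NCc1ccc(CNS(=O)(=O)c2ccc(Cl)cc2)cc1` gives 1 nM in an assay on MDA-MB-231 cells for displacement of a labelled ligand from C-X-C chemokine receptor type 4 (Homo sapiens), read by fluorescence and microscopy, with stated times of 10 min and 30 min; on this read-out higher numbers stand for an effect only at larger amounts of compound and lower numbers for an effect already at smaller amounts.
Compound 2 `COc1ccccc1C(=O)NCc1ccc(CNS(=O)(=O)c2cccc(C)c2)cc1` gives 1000 nM in this assay.

Compound 2 stands at the highest of the two numbers; its nearest neighbour, compound 1, sits far lower, well beyond the usual scatter. Compound 3 `Cc1cccc(S(=O)(=O)NCc2ccc(CNC(=O)c3ccccc3C)cc2)c1` differs from compound 2 by methyl in place of methoxy on an aromatic carbon. Going by the values given here, no measured pair isolates this single change, so the size of the step is open; given that compound 1 sits far lower, a move toward a lower number is expected, probably beyond the scatter but of uncertain size. The expected step is a 10-fold lower number from compound 2 to compound 3 (1.00 log units; beyond the scatter). Compound 3 is estimated at 100 nM, between 10 nM and 1000 nM.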

Compound 3, effective concentration (reported as EC, without a stated level of effect): 1000 nM
Estimate against measurement, compound 3: 10-fold (1.00 log units) below; measured number inside the range.
By their numbers in this assay, from the lowest: compound 1; then compounds 2 and 3 (each within the scatter of the next).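

On the carbonyl side, in this assay, 2-methoxyphenyl to 2-methylphenyl gives no change at the digits printed from compound 2 to compound 3 (within the scatter) for methyl in place of methoxy on this aromatic carbon, ortho to a large group. The large gap appears with the other change, a 1000-fold higher number from compound 1 to compound 3 (3.00 log units; beyond the scatter) for 3-methylphenyl in place of 4-chlorophenyl on a sulfonyl sulfur. No data shown bear on the reason for either step.
Open, as far as these compounds go, is whether that large step follows the chlorine or its place on the ring, and whether an amine or a carboxylic acid on the carbonyl-side aromatic carbon would also leave the number unchanged.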